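A few compounds are considered here, and "the series" means these few. Any claim that something is new, unique, unknown or untested is made for them only; others in the source may bear on it.

Measured compounds in a functional assay on the whole organism (blood, strain albino) with Mus musculus as the target, with stated times of 6 days and 4 h, at a dose of 0.4 mmol/kg by the oral route; a lower number here means less inhibition, a higher number more inhibition at the dose given (going by the name of the read-out):
- compound 1 `CCNC(=S)NS(=O)(=O)c1ccc(-n2nc(C(=O)O)cc2C)cc1`: -2%
- compound 2 `Cc1cc(C(=O)O)nn1-c1ccc(S(=O)(=O)NC(=S)Nc2ccccc2)cc1`: 0%
- compound 3 `CCCNC(=O)NS(=O)(=O)c1ccc(-n2nc(C(=O)O)cc2C)cc1`: 1%

All three share one core and differ only in the group on the sulfonamide nitrogen. None of them shows appreciable inhibition: the step of a number 3 percentage points higher from compound 1 to compound 3 (within the scatter), the step of a number 2 percentage points higher from compound 1 to compound 2 (within the scatter) and the step of a number 1 percentage points higher from compound 2 to compound 3 (within the scatter) are each inside the usual scatter, so compound 3 is not separated from compound 1 or compound 2, and the three numbers sit together close to zero.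

Compound 4 `CCCCNC(=S)NS(=O)(=O)c1ccc(-n2nc(C(=O)O)cc2C)cc1` is the next member. Relative to compound 3 the change is a group of 7 heavy atoms (5 carbon, 1 nitrogen, 1 sulfur; no ring) in place of a group of 6 heavy atoms (4 carbon, 1 nitrogen, 1 oxygen; no ring), on a sulfonamide nitrogen. The propylcarbamoyl group leaves and a group with no common name enters, at the same sulfonamide nitrogen. The step that bears on this most directly is a number 3 percentage points higher from compound 1 to compound 3 (within the scatter), which exchanged a sulfur-containing group for an oxygen-containing one at the same position and moved nothing beyond the scatter; the steps of a number 2 percentage points higher from compound 1 to compound 2 (within the scatter) and a number 1 percentage points higher from compound 2 to compound 3 (within the scatter) at the same nitrogen were equally flat. Compound 4 is therefore expected to remain at the same level, with the estimated step of a number 1 percentage points lower from compound 3 to compound 4 (within the scatter) not exceeding the scatter. For compound 4 the estimate in this assay is 0%, with a range from -10% to 10%.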

Compound 4, a percentage reported as inhibition, in the whole organism at one dose (the size of the read-out at that dose, not a potency): < 1%
Compound 4: only a limit was reported (the forecaster's own chance of this, stated with the estimate: 0%); the middle value does not contradict the limit.
By their numbers in this assay, from the lowest: compounds 1, 2 and 3 (each within the scatter of the next).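

In this assay compound 4 is reported only as a limit, < 1%, and not as a number. Going by these compounds alone, at the sulfonamide nitrogen, putting the sulfur-containing group with its butyl chain in place of the propylcarbamoyl group gives a number no higher from compound 3 to compound 4 (the limit leaves the size open), so this change adds no sign of inhibition to what the earlier compounds showed. The steps from compound 1 and compound 2 to compound 4 cannot be read, and the size of the step from compound 3 stays open, with the only reading for compound 4 being: the limit of < 1% in this assay, at which 1 of the 4 values shown sits.

Going by these compounds, it remains open whether any group at this nitrogen can raise inhibition clear of the level shared by compounds 1, 2 and 3. An amine on the chain, a longer chain such as octyl, or a methyl ester in place of the carboxylic acid of the shared core would test this.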